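Tracing a chloro step from compound 2

A few compounds are considered here, and "the series" means these few. Any claim that something is new, unique, unknown or untested is made for them only; others in the source may bear on it.

Compound 1 `COc1ccc(NC(=O)C(=O)c2cn(C(C)C)c3cccc(OC)c23)cn1` gives 7780 nM
Compound 2 `COc1ccc(NC(=O)C(=O)c2cn(C(C)C)c3ccccc23)cn1` gives 85 nM
Compound 3 `COc1ccc2c(C(=O)C(=O)Nc3ccc(OC)nc3)cn(C(C)C)c2c1` gives > 10000 nM (a limit of the assay, not a number)

In a functional assay on FaDu cells (Homo sapiens) for cytotoxicity, read by MTT assay, with a stated time of 72 h (a higher number here means that more compound is tolerated, a lower number that less compound is tolerated), compound 2 gives 85 nM and holds the lower of the two actual numbers in the series. The value of compound 3 is only a limit.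

Compound 4 `COc1ccc(NC(=O)C(=O)c2cn(C(C)C)c3cccc(Cl)c23)cn1` differs from compound 2 by chloro in place of hydrogen on an aromatic carbon and carries the chloro on the carbon that holds the methoxy of compound 1.

Within the data shown here, two measured steps bear on this change, and both are large. The closer one is a 92-fold lower number from compound 1 to compound 2 (1.96 log units; beyond the scatter) and read in reverse, it shows that a methoxy on this same carbon comes with a much higher number. The other is an at least 110-fold higher number from compound 2 to compound 3 (2.07 log units; beyond the scatter) with the methoxy on a different aromatic carbon. Neither step involves chloro, so its size carries over only loosely. A higher number is therefore expected in this assay but a smaller rise than the methoxy gave. The expected change is a 9.4-fold higher number from compound 2 to compound 4 (0.97 log units; beyond the scatter) as estimated here. Compound 4 is estimated at 800 nM with an expected range from 150 nM to 6000 nM in this assay.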

Compound 4, concentration lethal to 50% of the cells: 2130 nM
The estimate for compound 4 lay 2.7-fold (0.43 log units) below the measured number; measured number inside the range.
By their numbers in this assay, from the lowest: compound 2; then compound 4; then compound 1. At a limit, above all of these: compound 3.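

In this assay a group other than methoxy on this aromatic carbon also goes with a higher number: chloro in place of hydrogen gives a 25-fold higher number from compound 2 to compound 4 (1.40 log units; beyond the scatter) as a large step in its own right. The identity of the group still counts, with a 3.7-fold lower number from compound 1 to compound 4 (0.56 log units; beyond the scatter) as a modest step that stays beyond the scatter, so chloro and methoxy do not read as equal here. Among these compounds, on this one carbon the compounds now run from hydrogen in compound 2 through chloro in compound 4 to methoxy in compound 1, and with only two groups beyond hydrogen this is an order for these compounds and no general rule.

Going by these compounds, whether fluoro, an amine, a carboxylic acid or a longer chain such as ethoxy on this carbon would also raise the number stays open, as does whether chloro on the carbon that carries the methoxy of compound 3 would behave alike. Compound 3 itself stands at a limit and not at a number, and the size of its step cannot be set against the chloro step: the limit of > 10000 nM in this assay, at which 1 of the 4 values shown sits.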